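Cyclopropyl for propyl on the ring nitrogen

This account rests on a few compounds, and the source may have more. Where it says the series, first, only, none or still open, it means among the compounds named here.

Compound 1 `CCN1C(=O)[C@@H](NC(=O)c2cccc(C)c2)[C@@H](c2ccc(F)cc2)c2c(C)nn(-c3ccccc3)c21` and compound 2 `CCCn1nc(C)c2c1N(CC)C(=O)[C@@H](NC(=O)c1cccc(C)c1)[C@H]2c1ccc(F)cc1` share one core and differ only in the group on the aromatic nitrogen. In an ADME assay on HCC95 cells (Homo sapiens) for inhibition, read by CellTiter-Glo, with a stated time of 72 h (on this read-out lower numbers stand for an effect already at smaller amounts and higher numbers for an effect only at larger amounts of compound), compound 1 gives only a limit, > 25000 nM. In this assay compound 2 likewise gives only a limit, > 25000 nM. The step that the two limits leave unreadable from compound 1 to compound 2 cannot be read because of the limit of > 25000 nM in this assay, at which 2 of the 2 values shown sit. Compound 2 thus stands at the limit of this assay alongside compound 1, with no number in this series.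

Compound 3 `CCN1C(=O)[C@@H](NC(=O)c2cccc(C)c2)[C@@H](c2ccc(F)cc2)c2c(C)nn(C3CC3)c21` is to be measured in this assay. Its change from compound 2 is cyclopropyl in place of propyl on an aromatic nitrogen. Going by the values given here, the only measured step, which exchanged phenyl for propyl on the same aromatic nitrogen, was left unreadable by two limits, so no size can be taken from it. For compound 3 the step that the limit leaves unreadable from compound 2 to compound 3 is expected to be none beyond the scatter, most likely ending again at a limit. For compound 3 a value of 30000 nM is estimated, in a range from 8000 nM to 100000 nM.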

Compound 3, half-maximal effective concentration in the HCC95 assay: > 25000 nM
Compound 3 gave a limit, no number; the forecaster's own chance of this, stated with the estimate: 80%; the middle value is on the limit's open side.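

In the HCC95 assay compound 3 gives > 25000 nM, a limit and not a number; the steps linking compound 1, compound 2 and compound 3 cannot be read. In a physicochemical assay for solubility, measured as kinetic solubility, at pH 7.4 (on this read-out higher numbers stand for higher solubility and lower numbers for lower solubility), compound 2 gives 10900 nM and compound 3 gives 46100 nM. The compounds shown leave open whether any group on the aromatic nitrogen gives a number in the HCC95 assay.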